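The source may hold more compounds than are shown below. What is called first, only, known or untested is meant among the compounds shown, and "the series" means these compounds.

Measured so far:
Compound 1 `CCc1cc(CN2CC(C(=O)O)C2)sc1-c1ncc(-c2ccc(Oc3ccccc3)cc2)s1` — 42%
Compound 2 `CCc1cc(CN2CC(C(=O)O)C2)sc1-c1ncc(-c2ccc(OC(C)C)cc2)s1` — 52%

In a functional assay on the whole organism (spleen, spleen, strain LEW) for inhibition, with Rattus norvegicus as the target, with a stated time of 4 days, at a dose of 1 mg/kg by the oral route (a lower number here means less inhibition, a higher number more inhibition at the dose given (going by the name of the read-out)), compound 2 gives the higher of the two numbers, yet its gap to compound 1 lies within the scatter, as the step of a number 10 percentage points higher from compound 1 to compound 2 (within the scatter) shows. Compound 3 `CCCc1cc(-c2cnc(-c3sc(CN4CC(C(=O)O)C4)cc3CC)s2)ccc1OC(C)C` differs from compound 2 by propyl in place of hydrogen on an aromatic carbon. Among the measured compounds shown here, no measured step concerns propyl in place of hydrogen on an aromatic carbon, so the one step available, which is within the scatter, bears on it only indirectly, and no step beyond the scatter is expected in this assay. Compound 3 is therefore expected to give about 50%, between 30% and 70%, a step of a number 2 percentage points lower from compound 2 to compound 3 (within the scatter).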

Compound 3, a percentage reported as inhibition, in the whole organism at one dose (the size of the read-out at that dose, not a potency): 73%
Beside the measured number, compound 3's estimate is 23 percentage points below it; measured number above the stated range.
By their numbers in this assay, from the lowest: compounds 1 and 2 (each within the scatter of the next); then compound 3.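

In this assay, propyl in place of hydrogen on the aromatic carbon ortho to an isopropoxy group gives a number 21 percentage points higher from compound 2 to compound 3 (beyond the scatter), so this carbon takes a substituent with a gain in the read-out at this dose. The earlier change on the oxygen, a number 10 percentage points higher from compound 1 to compound 2 (within the scatter), had moved no number beyond the scatter, and this is the first change shown that does. No measurement at hand bears on the reason for the rise. From the compounds shown here alone, whether methyl, a longer chain such as butyl, or an amine at this carbon would do the same remains open. So does whether propyl would bring a similar step with the phenyl on the oxygen of compound 1.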